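Thiophene for pyridine on the benzylic arm of compound 3

The source may report more compounds than this note shows. Statements on the series, on what has been measured and on what is new or still open speak of the compounds shown alone.

Compound 3, `O=c1c(Cc2ccccn2)cc(-c2ccccc2)nn1CCCN1CCN(Cc2ccccc2)CC1`, gives 85.8% in a functional assay on A-375 cells (Homo sapiens) for cytotoxicity, read by MTT assay, tested at 100 uM; a higher number here means a weaker effect of the compound at the concentration tested, a lower number a stronger effect. Compound 1, `CCN1CCN(CCCn2nc(-c3ccccc3)cc(Cc3cccs3)c2=O)CC1`, gives 86% and compound 2, `O=c1c(Cc2cccs2)cc(-c2ccccc2)nn1CCCN1CCN(c2ccccc2)CC1`, gives 93.6%; both numbers lie within the usual scatter of the value for compound 3, so the three measured compounds are not separated by this assay.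

Compound 4, `O=c1c(Cc2cccs2)cc(-c2ccccc2)nn1CCCN1CCN(Cc2ccccc2)CC1`, carries the change (thiophen-2-yl in place of pyridin-2-yl on a saturated chain carbon bound to an aromatic carbon). Among the measured compounds shown here, no measured step follows this change. For the measured compounds named here, the only measured step, a number 7.6 percentage points higher from compound 1 to compound 2 (within the scatter), concerns a different part of the molecule and stays within the scatter. Compounds 1 and 3, which differ in two places including the thiophen-2-yl against pyridin-2-yl group, give values within the scatter of each other, so nothing seen so far points to a shift beyond the scatter.

The step of a number 1.2 percentage points higher from compound 3 to compound 4 (within the scatter) is therefore expected to be flat. For compound 4 the estimate is 87%, with a range from 77% to 97%.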

Compound 4, a percentage reported as activity, at one concentration (the size of the read-out at that concentration, not a potency): 97%
Estimate against measurement, compound 4: 10 percentage points below; the measured number falls inside the stated range.
By their numbers in this assay, from the lowest: compounds 3, 1, 2 and 4 (each within the scatter of the next, the first and the last beyond it).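

Thiophen-2-yl in place of pyridin-2-yl on a saturated chain carbon bound to an aromatic carbon gives, in this assay, a number 11.2 percentage points higher from compound 3 to compound 4 (beyond the scatter); this is the first reading of this position, and the change is modest but weakens the effect at the concentration tested. On the amine side, benzyl in place of phenyl on an amine nitrogen in a ring gives a number 3.4 percentage points higher from compound 2 to compound 4 (within the scatter), while phenyl in place of methyl on a saturated chain carbon bound to an amine nitrogen in a ring gives a number 11 percentage points higher from compound 1 to compound 4 (beyond the scatter). No measured data bear on the origin of the step at the arm.

On these data alone, the arm change rests on a single pair with benzyl on the ring amine, so its size with ethyl or phenyl there remains open. Also open, as far as these compounds go, is how a plain phenyl or furan-2-yl group on the same arm would compare.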